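The source may report more compounds than this note shows. Statements on the series, on what has been measured and on what is new or still open speak of the compounds shown alone.

- compound 1 `COc1cc(OC)c(Cl)c(-c2ccc3c(NC(=O)c4ccc(C5CCN(C)CC5)cc4)n[nH]c3n2)c1Cl`: 8.2 nM
- compound 2 `COc1cc(OC)c(Cl)c(-c2ccc3c(NC(=O)c4ccc(N5CCN(C6CCC6)CC5)cc4)n[nH]c3n2)c1Cl`: 2.3 nM

In a functional assay on NCI-H1581 cells (Homo sapiens) for antiproliferative activity, read by CCK-8 assay, with a stated time of 72 h (a higher number here means a weaker inhibitor, a lower number a stronger inhibitor), compound 2 at 2.3 nM has the lower of the two numbers, so it is the stronger inhibitor so far. Compound 3 `C=CCN1CCN(c2ccc(C(=O)Nc3n[nH]c4nc(-c5c(Cl)c(OC)cc(OC)c5Cl)ccc34)cc2)CC1` has allyl in place of cyclobutyl on an amine nitrogen in a ring. For the measured compounds named here, only one measured step bears on this, and only loosely: a 3.6-fold lower number from compound 1 to compound 2 (0.55 log units; beyond the scatter). That modest step replaced the whole 1-methylpiperidin-4-yl group, a larger swap than this one, so no step beyond the scatter is expected here. The estimate implies a 1.3-fold higher number from compound 2 to compound 3 (0.12 log units; within the scatter), an expected shift. For compound 3 the expected value is 3 nM, with an estimated range of 1.2 nM to 8 nM.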

Compound 3, half-maximal inhibitory concentration: 3.3 nM
The estimate for compound 3 lay 1.1-fold (0.04 log units) below the measured number, within the range that was stated.
By their numbers in this assay, from the lowest: compounds 2 and 3 (each within the scatter of the next); then compound 1.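

Putting allyl in place of cyclobutyl on this amine nitrogen gives a 1.4-fold higher number from compound 2 to compound 3 (0.16 log units; within the scatter) in this assay, so at this level of resolution the nitrogen takes an open group with a double bond as well as a four-membered ring. The 4-allylpiperazin-1-yl group also keeps a clear edge over 1-methylpiperidin-4-yl, with a 2.5-fold lower number from compound 1 to compound 3 (0.40 log units; beyond the scatter), so that edge now appears with two different piperazines. No measurement here offers a reason for these numbers.

Still open, as far as these compounds go, is how a 2-hydroxyethyl group, a longer carbon chain or a carboxylic acid would fare on this nitrogen. It is also unknown how much size this position tolerates before the number rises beyond the scatter.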